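The compounds below may be only part of what the source reports. "The series", "measured", "known", "first", "only" and "open" are said of these compounds alone.

- Compound 1 `CC1(/C=C/c2ccc(C(F)(F)F)cc2)C=CC(=O)O1`: 12300 nM
- Compound 2 `COc1ccc(/C=C/C2(C)C=CC(=O)O2)cc1OC`: 927000 nM

In a functional assay on HT-29 cells (Homo sapiens) for inhibition, read by sulforhodamine B assay, with a stated time of 48 h (on this read-out lower numbers stand for stronger inhibition of growth and higher numbers for weaker inhibition of growth), compound 2 gives 927000 nM, the higher of the two numbers. Compound 1, at 12300 nM, lies below it by a margin well beyond the scatter, which makes compound 2 the weaker of the pair.

The next compound to consider is compound 3 `COc1ccc(/C=C/C2(C)C=CC(=O)O2)cc1`. It differs from compound 2 by one structural change, hydrogen in place of methoxy on an aromatic carbon, ortho to a methoxy group. Going by the values given here, no measured pair isolates this change, so any expectation rests on thin evidence. Among the compounds with values here, the only guide is that compound 2, with its two methoxy groups, gives 927000 nM, while compound 1, with trifluoromethyl and no methoxy group, gives 12300 nM. A moderate move towards a lower number in this assay, beyond the scatter, therefore seems more likely than no change. The estimated size of this move is a 6.2-fold lower number from compound 2 to compound 3 (0.79 log units; beyond the scatter). Compound 3 is expected at 150000 nM, with an estimated range of 25000 nM to 800000 nM.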

Compound 3, concentration for total growth inhibition: 92900 nM
The estimate for compound 3 lay 1.6-fold (0.21 log units) above the measured number; low and high end bracket the measured number.
By their numbers in this assay, from the lowest: compound 1; then compound 3; then compound 2.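

In this assay, going by these compounds alone, the pair of compound 2 and compound 3 isolates a single change for the first time: hydrogen in place of methoxy on an aromatic carbon, ortho to a methoxy group, gives a 10-fold lower number from compound 2 to compound 3 (1.00 log units; beyond the scatter) and so the loss of this methoxy group goes with stronger inhibition of growth. With one methoxy group left, compound 3 can also be read directly against compound 1, where methoxy in place of trifluoromethyl on an aromatic carbon gives a 7.6-fold higher number from compound 1 to compound 3 (0.88 log units; beyond the scatter) and so the trifluoromethyl compound shows the stronger inhibition of growth of that pair. Nothing available here accounts for either step.

The compounds shown leave open how a chlorine atom, an amine or a carboxylic acid on the aromatic carbon that carries hydrogen in compound 3 would compare with hydrogen and methoxy at that place. They also leave open whether removing the remaining methoxy group, leaving hydrogen alone on that aromatic carbon, would lower the number again or raise it.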